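Dichloroacetamide series: methyl in place of phenyl

A few compounds are considered here, and "the series" means these few. Any claim that something is new, unique, unknown or untested is made for them only; others in the source may bear on it.

Compound 1 `O=C(Nc1cccc(-c2ccc(-c3ccccc3)cc2)c1)C(Cl)Cl` carries a phenyl group on the shared core. In a functional assay on A549 cells (Homo sapiens) for cytotoxicity, read by MTT assay, with a stated time of 68 h (a higher number here means a weaker inhibitor, a lower number a stronger inhibitor), compound 1 gives only a limit, > 50000 nM, and not a number. That reading sits at the limit of > 50000 nM in this assay, at which 1 of the 3 values shown sits. Compound 2 `COc1ccccc1-c1cc(NC(=O)C(Cl)Cl)cc(-c2ccccc2OC)c1` gives 25500 nM in this assay. Compound 3 `CCOc1ccc(-c2cc(NC(=O)C(Cl)Cl)cc(-c3ccc(OCC)cc3)c2)cc1` gives 8050 nM in this assay. Among the measured compounds shown here, none of these three compounds differ from one another in a single place, so no step between measured compounds is available, and the position of compound 1 relative to the other two can only be stated as a limit against two numbers.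

Compound 4 `Cc1ccc(-c2cccc(NC(=O)C(Cl)Cl)c2)cc1` differs from compound 1 in one place: methyl in place of phenyl on an aromatic carbon. For the measured compounds named here, with no measured step of this kind to lean on, and with compound 1 known only as a limit, the expectation is a change in this assay from compound 1 to compound 4 of no more than the scatter, in either direction. Compound 4 is estimated at 50000 nM in this assay, with a range from 20000 nM to 100000 nM. The step this estimate implies is a number no higher from compound 1 to compound 4 (the limit leaves the size open).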

Compound 4, half-maximal inhibitory concentration: 8300 nM
Beside the measured number, compound 4's estimate is 6.0-fold (0.78 log units) above it, outside the stated range (below it).
By their numbers in this assay, from the lowest: compounds 3 and 4 (each within the scatter of the next); then compound 2. At a limit, above all of these: compound 1.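

Replacing phenyl with methyl on this aromatic carbon, para to a large group, gives an at least 6.0-fold lower number from compound 1 to compound 4 (0.77 log units; beyond the scatter) in this assay. This is the only single-place step in the compounds shown, and it lies beyond the scatter, so the terminal phenyl of compound 1 is not required for a measurable reading in this assay. Compound 1 stands only as a limit, so the true size of the step stays unknown: the limit of > 50000 nM in this assay, at which 1 of the 4 values shown sits.

With only phenyl and methyl compared at this carbon, two groups cannot establish a trend for this position. From the compounds shown here alone, how an amine, a carboxylic acid or a propyl chain in the same place would read in this assay remains open.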